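This account rests on a few compounds, and the source may have more. Where it says the series, first, only, none or still open, it means among the compounds named here.

In a functional assay on K562 cells (Homo sapiens) for cytotoxicity, read by MTT assay, with a stated time of 24 h (a lower number here means a stronger inhibitor, a higher number a weaker inhibitor), compound 1 `CN1C/C(=C\c2ccc(F)cc2)C(=O)/C(=C/c2cccc([N+](=O)[O-])c2)C1` gives 11300 nM. Compound 2 `CN1C/C(=C\c2ccc(Cl)cc2)C(=O)/C(=C/c2cccc([N+](=O)[O-])c2)C1` reaches only a limit of the assay here, > 20000 nM. The change between those two, (chloro in place of fluoro on an aromatic carbon), gave an at least 1.7-fold higher number from compound 1 to compound 2 (0.24 log units; that floor lies within the scatter); this reading rests on (the limit of > 20000 nM in this assay, at which 1 of the 3 values shown sits). Compound 3 `CN1C/C(=C\c2ccc(F)cc2)C(=O)/C(=C/c2ccc(C#N)cc2)C1` gives 11300 nM in this assay, so its value sits level with that of compound 1; how its core differs from the core of compound 1 is not broken down here. Compound 4 `CN1C/C(=C\c2ccc(Cl)cc2)C(=O)/C(=C/c2ccc(C#N)cc2)C1` has not yet been measured. Among the compounds with values here, it differs from compound 3 by chloro in place of fluoro on an aromatic carbon, the same change as the one made from compound 1 to compound 2. From that earlier step, the expected step is a 1.8-fold higher number from compound 3 to compound 4 (0.25 log units; within the scatter), quite possibly again ending at a limit rather than a number. Compound 4 is expected to give 20000 nM, between 9000 nM and 50000 nM.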

Compound 4, half-maximal inhibitory concentration: 13300 nM
Estimate against measurement, compound 4: 1.5-fold (0.18 log units) above; the range from low to high includes it.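

In this assay, chloro in place of fluoro on the second core gave a 1.2-fold higher number from compound 3 to compound 4 (0.07 log units; within the scatter), so on this core the change shifts the number no more than repeat measurements would. Compound 2 stands at a limit of the assay, > 20000 nM, and not at a true number. The result therefore shows no clear effect on this second core, but it does not show that the change acts alike on both cores: the same change on two cores in this assay, an at least 1.7-fold higher number (0.24 log units; that floor lies within the scatter) from compound 1 to compound 2 and a 1.2-fold higher number (0.07 log units; within the scatter) from compound 3 to compound 4; the limit leaves it open whether they differ

The compounds shown leave open how other groups on that aromatic carbon, such as an amine or a carboxylic acid, would read. They also leave open whether the same change would behave alike on cores beyond these two.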